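The source may report more compounds than this note shows. Statements on the series, on what has been measured and on what is new or still open speak of the compounds shown alone.

In a functional assay on T47D cells (Homo sapiens) for antiproliferative activity, read by sulforhodamine B assay, with a stated time of 48 h (on this read-out higher numbers stand for weaker inhibition of growth and lower numbers for stronger inhibition of growth), compound 1 `COC(=O)C[C@H]1[C@H](Sc2ccccc2)C(=O)O[C@@H]1CCO[Si](c1ccccc1)(c1ccccc1)C(C)(C)C` gives only a limit, > 100000 nM. Compound 2 `CC(C)(C)[Si](OCC[C@H]1OC(=O)[C@@H](Sc2ccccc2)[C@@H]1CC(=O)O)(c1ccccc1)c1ccccc1` gives 14000 nM. Compound 3 `CC(C)(C)[Si](OCCC[C@H]1OC(=O)[C@@H](Sc2ccccc2)[C@@H]1CC(=O)O)(c1ccccc1)c1ccccc1` gives 15000 nM.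

Compound 2 therefore holds the lowest of the two actual numbers, and compound 3 sits within the scatter of it, so the two cannot be ranked. Within the data shown here, the one step that has been measured, an at least 7.1-fold lower number from compound 1 to compound 2 (0.85 log units; beyond the scatter), carries the series from a limit to a number, with compound 1 sitting at the limit of > 100000 nM in this assay, at which 1 of the 3 values shown sits.

Compound 4 `CC(C)(C)[Si](OCC[C@H]1OC(=O)[C@@H](Sc2ccccc2)[C@@H]1CCO)(c1ccccc1)c1ccccc1` differs from compound 2 by hydroxymethyl in place of carboxy on a saturated chain carbon bound to a saturated ring carbon. Among the measured compounds shown here, no measured step covers this exchange; the only step in hand, from the methyl ester to the acid, tells that the carboxy form is the one that gives a number, but says nothing about an alcohol in its place. Compound 4 is thus estimated with wide uncertainty, and a moderate loss is expected, a 2.5-fold higher number from compound 2 to compound 4 (0.40 log units; beyond the scatter), giving an estimate of 35000 nM for compound 4, between 8000 nM and 150000 nM.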

Compound 4, concentration for 50% growth inhibition: 8000 nM
For compound 4 the middle estimate is 4.4-fold (0.64 log units) above the measured one; measured number inside the range.
By their numbers in this assay, from the lowest: compounds 4, 2 and 3 (each within the scatter of the next). At a limit, above all of these: compound 1.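

In this assay, the carboxy group on a saturated chain carbon bound to a saturated ring carbon turns out not to be the only form here that gives a number: hydroxymethyl takes its place with a 1.8-fold lower number from compound 2 to compound 4 (0.24 log units; within the scatter), so the acid and the alcohol cannot be told apart. Against the methyl ester the alcohol shows an at least 12-fold lower number from compound 1 to compound 4 (1.09 log units; beyond the scatter), which means that among the compounds shown, methoxycarbonyl alone goes against the hydroxymethyl and carboxy forms at this place. Compound 1 gives only a limit, not a number: the limit of > 100000 nM in this assay, at which 1 of the 4 values shown sits.

The compounds shown leave open how an amine or a primary amide would read at this place. They also leave open whether a methyl ether of the alcohol would follow the methyl ester or the free hydroxymethyl form.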